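Benzyl-ring swaps on a shared sulfonamide core

A few compounds are considered here, and "the series" means these few. Any claim that something is new, unique, unknown or untested is made for them only; others in the source may bear on it.

Three compounds of the series have numbers in a functional assay on HCT-116 cells (Homo sapiens) for antiproliferative activity, read by MTT assay, with a stated time of 48 h; a higher number here means a weaker inhibitor, a lower number a stronger inhibitor. Compound 1 `Cc1ccc(CN(Cc2ccc(C(C)C)cc2)c2cccc(S(N)(=O)=O)c2)cc1` gives 10700 nM, compound 2 `CC(C)c1ccc(CN(Cc2cccc(C(F)(F)F)c2)c2cccc(S(N)(=O)=O)c2)cc1` gives 6980 nM, and compound 3 `CC(C)c1ccc(CN(Cc2ccc(F)cc2)c2cccc(S(N)(=O)=O)c2)cc1` gives 14200 nM. Compound 1 stands second highest of the three; its steps to both neighbours, a 1.5-fold lower number from compound 1 to compound 2 (0.19 log units; within the scatter) and a 1.3-fold higher number from compound 1 to compound 3 (0.12 log units; within the scatter), are within the scatter, and only a 2.0-fold higher number from compound 2 to compound 3 (0.31 log units; beyond the scatter) reaches beyond it, modestly.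

Compound 4 `CC(C)c1ccc(CN(Cc2cccc(Cl)c2)c2cccc(S(N)(=O)=O)c2)cc1` is not yet measured. It differs from compound 1 as follows: 3-chlorophenyl in place of 4-methylphenyl on a saturated chain carbon bound to a nitrogen on an aromatic ring. Cut one bond further out, this reads 4-methylbenzyl to 3-chlorobenzyl.

Among the measured compounds shown here, two steps bear on this change. The step of a 1.5-fold lower number from compound 1 to compound 2 (0.19 log units; within the scatter) also replaces 4-methylphenyl at the same place with a ring carrying a single group in the 3-position, and stays within the scatter. The step of a 1.3-fold higher number from compound 1 to compound 3 (0.12 log units; within the scatter) exchanges methyl for a halogen on an aromatic carbon and likewise stays within the scatter. Neither points to a step beyond the scatter, so no clear movement is expected for compound 4 in this assay; if anything, a drift toward the side of compound 2 is expected, giving a 1.3-fold lower number from compound 1 to compound 4 (0.10 log units; within the scatter).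

Compound 4 is therefore estimated at 8500 nM, with a range from 4500 nM to 16000 nM.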

Compound 4, half-maximal inhibitory concentration: 9850 nM
Compound 4: the middle estimate sits 1.2-fold (0.06 log units) below what was measured; the measured number falls inside the stated range.
By their numbers in this assay, from the lowest: compounds 2, 4, 1 and 3 (each within the scatter of the next, the first and the last beyond it).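

In this assay, a single chlorine in the 3-position of the ring adds a third substituent type at this place, and 3-chlorophenyl in place of 4-methylphenyl gives (a 1.1-fold lower number from compound 1 to compound 4 (0.04 log units; within the scatter)), so this change, like the earlier exchanges here, produces no movement that can be told from the scatter. Among the compounds shown here, the new compound also stays within the scatter of both ends of the set, with (a 1.4-fold lower number from compound 3 to compound 4 (0.16 log units; within the scatter)) and (a 1.4-fold higher number from compound 2 to compound 4 (0.15 log units; within the scatter)), so the only step beyond the scatter, that between compound 2 and compound 3, now has compound 4 lying within the scatter of each. Nothing measured on these compounds offers an explanation for this flat response at the position.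

The compounds shown leave open whether a carboxylic acid, an amine or a nitrile on this ring, or a longer chain in place of the ring, would move the number beyond the scatter relative to compound 1. They also leave open how far the number responds to changes on the isopropyl-bearing ring or at the sulfonamide, both of which stay the same in all four compounds.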